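Working notes: from compound 1 to compound 3

A few compounds are considered here, and "the series" means these few. Any claim that something is new, unique, unknown or untested is made for them only; others in the source may bear on it.

Measured so far:
compound 1 `O=C(CCCCCCC(=O)Nc1ccc(C(F)(F)F)cc1)NO` gives 2200 nM
compound 2 `O=C(CCCCCCC(=O)Nc1ccccc1Br)NO` gives 17500 nM

Both values come from a functional assay on SK-BR-3 cells (Homo sapiens) for antiproliferative activity, with a stated time of 48 h; on this read-out lower numbers stand for an effect already at smaller amounts and higher numbers for an effect only at larger amounts of compound. Compound 1 (2200 nM) has the lower of the two numbers, and compound 2 (17500 nM) lies above it, beyond the usual scatter. Compound 3 `CN(C)c1ccc(NC(=O)CCCCCCC(=O)NO)cc1` is not yet measured. It carries dimethylamino in place of trifluoromethyl on an aromatic carbon, para to a large group (dimethylamino in place of trifluoromethyl on an aromatic carbon). Among the compounds with values here, no measured step isolates this change, so the expectation has little direct support. With no clear direction to go on, only a small step in this assay is expected, within the scatter. The expected 1.1-fold higher number from compound 1 to compound 3 (0.06 log units; within the scatter) is therefore modest and its direction uncertain. Compound 3 is estimated at 2500 nM (expected range 800 nM to 8000 nM).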

Compound 3, half-maximal effective concentration: 4200 nM
Compound 3: middle estimate off by 1.7-fold (0.23 log units), on the low side; low and high end bracket the measured number.
By their numbers in this assay, from the lowest: compounds 1 and 3 (each within the scatter of the next); then compound 2.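

In this assay, within the data shown here, the first readable step at this position is a 1.9-fold higher number from compound 1 to compound 3 (0.28 log units; within the scatter), for dimethylamino in place of trifluoromethyl on an aromatic carbon, para to a large group. The exchange alters the heavy atoms and brings in a hydrogen-bond acceptor, yet the two compounds cannot be told apart on this read-out, so this position tolerates this particular change within the scatter. No measurement at hand gives a reason for this outcome. Going by these compounds, whether the same holds for a primary amine, a carboxylic acid or a nitrile at this place remains open. Also open, on these data alone, is how a longer chain on the core of compound 1 would read, and compound 2 differs from compound 1 in more than one place, so it does not settle either question.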